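This account rests on a few compounds, and the source may have more. Where it says the series, first, only, none or still open, it means among the compounds named here.

Among the measured compounds shown here, compound 2 `CC1CCN(c2c(S(=O)(=O)c3ccccc3)cnc3ccc(Cl)cc23)CC1` stands lowest of the three numbers known so far. In an assay on isolated protein for displacement of a labelled ligand from metabotropic glutamate receptor 5 (Homo sapiens), with a stated time of 60 min, tested at 1 uM (a higher number here means more inhibition at the concentration tested (going by the name of the read-out), a lower number less inhibition), compound 2 gives 59%. Its parent compound 1 `CC1CCN(c2c(S(=O)(=O)c3ccccc3)cnc3ccccc23)CC1` gives 89.2%, and compound 3 `Cc1ccc2ncc(S(=O)(=O)c3cc(F)cc(F)c3)c(N3CCC(C)CC3)c2c1` gives 72%. For the measured compounds named here, the only measured single change, a number 30.2 percentage points lower from compound 1 to compound 2 (beyond the scatter), came with chloro in place of hydrogen on an aromatic carbon of the shared core. Going by the values given here, compound 3 differs from compound 2 in more than one place, so its value shows only that a phenyl ring bearing two fluorines, together with a methyl on the core, still gives a middling number.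

Compound 4 `CC1CCN(c2c(S(=O)(=O)c3cccc(F)c3)cnc3ccc(Cl)cc23)CC1` differs from compound 2 by fluoro in place of hydrogen on an aromatic carbon, sitting meta to a large group. Among the compounds with values here, no measured step touches this ring alone, and the large step on the core does not bear on it. With no guide from the data, the step is expected to stay within the scatter: a number 1 percentage points higher from compound 2 to compound 4 (within the scatter). Compound 4 is therefore estimated to give 60%, in a range from 40% to 80%.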

Compound 4, a percentage reported as inhibition, at one concentration (the size of the read-out at that concentration, not a potency): 58%
Beside the measured number, compound 4's estimate is 2 percentage points above it, and the stated range covers the measured number.
By their numbers in this assay, from the lowest: compounds 4 and 2 (each within the scatter of the next); then compound 3; then compound 1.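

In this assay, the change from phenyl to 3-fluorophenyl gives a number 1 percentage points lower from compound 2 to compound 4 (within the scatter), so a fluoro at this place on the phenyl ring leaves the read-out unchanged within the usual scatter. Among the compounds shown here, this is the only measured step on that ring, and it stands apart from the step on the shared core, a number 30.2 percentage points lower from compound 1 to compound 2 (beyond the scatter), which lies beyond the scatter. Nothing available explains why one single-atom change shifts the number and the other does not.

The compounds shown leave open whether a larger group at the same place, such as methoxy or an amine, would also leave the number unchanged. They also leave open whether fluoro would behave the same way on the core of compound 1, which carries no chloro.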